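Aryl swap on the carbonyl carbon: expected growth inhibition

The source may report more compounds than this note shows. Statements on the series, on what has been measured and on what is new or still open speak of the compounds shown alone.

Compound 2 `COc1ccc(C(=O)/C=C/c2cc(-c3cc(OC)c(OC)c(OC)c3)n[nH]2)cc1` gives 3940 nM in a functional assay on A498 cells (Homo sapiens) for inhibition, read by sulforhodamine B assay, with a stated time of 48 h; a lower number here means a stronger inhibitor of growth, a higher number a weaker inhibitor of growth. Within the data shown here, of the two numbers on hand it is the lowest, but its nearest neighbour, compound 1 `COc1cc(-c2cc(/C=C/C(=O)c3ccc(N)cc3)[nH]n2)cc(OC)c1OC`, gives 4330 nM, and the only measured step, a 1.1-fold lower number from compound 1 to compound 2 (0.04 log units; within the scatter), stays within the scatter, so the two compounds cannot be ranked against each other.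

Compound 3 `COc1cc(-c2cc(/C=C/C(=O)c3ccc(F)c(F)c3)[nH]n2)cc(OC)c1OC` differs from compound 2 in one place: 3,4-difluorophenyl in place of 4-methoxyphenyl on a carbonyl carbon. Among the measured compounds shown here, the one measured step concerns a different part of the molecule, the aromatic carbon that carries amino or methoxy, and there the change made no difference worth noting, as a 1.1-fold lower number from compound 1 to compound 2 (0.04 log units; within the scatter) shows. For the measured compounds named here, no measured step touches the aryl group on the carbonyl carbon, so there is no direct guide for this exchange; the single comparison available suggests the ring at that end tolerates small changes. The step from compound 2 to compound 3 in this assay is therefore expected to be small, a 1.1-fold higher number from compound 2 to compound 3 (0.06 log units; within the scatter), with no clear direction. Compound 3 is estimated at 4500 nM in this assay, with an expected range from 1500 nM to 14000 nM.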

Compound 3, concentration for total growth inhibition: 7130 nM
For compound 3 the middle estimate is 1.6-fold (0.20 log units) below the measured one, within the range that was stated.
By their numbers in this assay, from the lowest: compounds 2, 1 and 3 (each within the scatter of the next).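

The aryl group on the carbonyl carbon can now be read directly in this assay: 3,4-difluorophenyl in place of 4-methoxyphenyl gives a 1.8-fold higher number from compound 2 to compound 3 (0.26 log units; within the scatter) and 3,4-difluorophenyl in place of 4-aminophenyl gives a 1.6-fold higher number from compound 1 to compound 3 (0.22 log units; within the scatter) as the second reading at this place. Both steps lie within the scatter, so 4-aminophenyl, 4-methoxyphenyl and 3,4-difluorophenyl cannot be ranked here, even though the exchange replaces a group carrying a hydrogen-bond acceptor with one carrying none. Nothing further is available to explain these numbers.

On these data alone, whether this position stays as undemanding for groups of another kind, such as 4-carboxyphenyl, 4-(dimethylamino)phenyl or a non-aromatic cyclohexyl, remains open. As far as these compounds go, all three compounds share the rest of the structure, so it is also open how the numbers respond to changes elsewhere in the shared core, for instance a methyl group on the ring nitrogen that carries the hydrogen, or a saturated chain in place of the double-bonded one.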